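From Butyl to Methyl: Estimating Compound 4

This account rests on a few compounds, and the source may have more. Where it says the series, first, only, none or still open, it means among the compounds named here.

Three compounds have been measured in a functional assay on HepG2 cells (Homo sapiens) for antiproliferative activity, read by MTT assay, with a stated time of 3 days; on this read-out higher numbers stand for weaker inhibition and lower numbers for stronger inhibition:
Compound 1, `CCCCC#Cc1cn(C/C=C/CN2C(=O)c3ccccc3C2=O)c(=O)[nH]c1=O`, gives 7900 nM.
Compound 2, `CCCCc1ccc(C#Cc2cn(C/C=C\CN3C(=O)c4ccccc4C3=O)c(=O)[nH]c2=O)cc1`, gives 40000 nM.
Compound 3, `CCCCCc1ccc(C#Cc2cn(C/C=C/CN3C(=O)c4ccccc4C3=O)c(=O)[nH]c2=O)cc1`, gives 4300 nM.

Compound 2 gives the highest number of the three; the nearest measured value belongs to compound 1, and that gap lies beyond the scatter, as does the larger gap to compound 3. Among the measured compounds shown here, the single one-step comparison available, a 1.8-fold lower number from compound 1 to compound 3 (0.26 log units; within the scatter), exchanges a plain chain for a substituted ring and stays within the scatter.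

Compound 4, `Cc1ccc(C#Cc2cn(C/C=C\CN3C(=O)c4ccccc4C3=O)c(=O)[nH]c2=O)cc1`, differs from compound 2 by hydrogen in place of propyl on a saturated chain carbon bound to an aromatic carbon. For the measured compounds named here, no measured pair shows this change, nor any shortening of a chain attached to the aromatic ring; the one step that was measured concerns a different part of the molecule and was small. There is therefore no basis for expecting a move beyond the scatter in this assay in either direction. Near the value of compound 2, compound 4 is expected to give 50000 nM, within a range of 15000 nM to 150000 nM. The step implied by that estimate, a 1.3-fold higher number from compound 2 to compound 4 (0.10 log units; within the scatter), is expected to stay within the scatter.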

Compound 4, half-maximal inhibitory concentration: 68000 nM
Compound 4: the middle estimate sits 1.4-fold (0.13 log units) below what was measured, and the stated range covers the measured number.
By their numbers in this assay, from the lowest: compounds 3 and 1 (each within the scatter of the next); then compounds 2 and 4 (each within the scatter of the next).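

In this assay, the change from 4-butylphenyl to 4-methylphenyl gives a 1.7-fold higher number from compound 2 to compound 4 (0.23 log units; within the scatter) and so stays within the scatter. Among the compounds shown here, this is the first measured reading of a change on a saturated chain carbon bound to an aromatic carbon: in this one pair, three carbon atoms of the chain leave without a change in the number that can be told from the scatter, so the read-out does not depend strongly on the length of this chain between butyl and methyl. No available measurement bears on why the number holds here.

The compounds shown leave open whether this insensitivity extends beyond plain carbon chains, since a methoxy group, an amine or a carboxylic acid in the place of the methyl group could behave differently, and a single pair cannot settle that. Going by these compounds, it also remains open whether the same shortening would likewise stay within the scatter in compounds with the double-bond geometry of compound 3, or with a chain longer than pentyl on the ring.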